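The source may hold more compounds than are shown below. What is called first, only, known or untested is meant among the compounds shown, and "the series" means these compounds.

Compound 1 `CCCCCC=C(c1cc(Cl)c(OC)c(C(=O)OC)c1)c1cc(Cl)c(OC)c(C(=O)OC)c1`: "not determined" (no result reported).
Compound 2 `COC(=O)CCCC=C(c1cc(Br)c(OC)c(C(=O)OC)c1)c1cc(Br)c(OC)c(C(=O)OC)c1`: 91000 nM.

The study concerns two closely related compounds that share a core carrying two substituted aromatic rings on a double-bonded chain carbon, and it then turns to a third. In an ADME assay on MT4 cells (Homo sapiens) for cytotoxicity (on this read-out lower numbers stand for higher toxicity in this test and higher numbers for lower toxicity in this test), compound 2 gives 91000 nM. Among the measured compounds shown here, that is the only number available: compound 1 was included in the set but its entry in this assay reads "not determined" (no result reported), so compound 2 stands alone and there is no measured step against which to gauge it.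

Compound 3 `COC(=O)c1cc(C(=CCCCc2ccccc2)c2cc(Br)c(OC)c(C(=O)OC)c2)cc(Br)c1OC` follows from compound 2 by one change: phenyl in place of methoxycarbonyl on a saturated chain carbon, three bonds along the chain from a double-bonded chain carbon.

For the measured compounds named here, with no measured pair of compounds differing in a single place, the size of this step cannot be read from data; the account can only voice an expectation. A modest shift toward lower numbers in this assay, meaning somewhat higher toxicity for compound 3, is expected, roughly a 1.8-fold lower number from compound 2 to compound 3 (0.26 log units; within the scatter), although a result within the usual scatter around compound 2 would not be surprising. Compound 3 is therefore estimated at 50000 nM, with a plausible range from 20000 nM to 120000 nM.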

Compound 3, half-maximal cytotoxic concentration: > 198000 nM
Compound 3 was reported as a limit (the forecaster's own chance of this, stated with the estimate: 25%); middle value at least 3.9-fold (0.59 log units) away from the limit.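

In this assay compound 3 gives > 198000 nM, and this value is a limit of the assay, not a number. Among the compounds shown here, at the end of the chain, on a saturated chain carbon three bonds along from a double-bonded chain carbon, phenyl in place of methoxycarbonyl thus gives an at least 2.1-fold higher number from compound 2 to compound 3 (0.33 log units; beyond the scatter), the first step in this set that can be read, and it lies beyond the scatter in the direction of lower toxicity in this test. The methoxycarbonyl group at this position is therefore not required for a high number on this read-out, and the step is bounded on one side only, so its full size remains unknown: the limit of > 198000 nM in this assay, at which 1 of the 3 values shown sits.

Steps involving compound 1 cannot be read, which leaves the effect of chlorine in place of bromine on the rings without a number in this assay. Also open, on these data alone, is how a carboxylic acid or an amine at this chain end, or a longer chain carrying the phenyl, would compare with compound 2 and compound 3.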